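Swapping the allyl group on sulfur in compound 3

The compounds below may be only part of what the source reports. "The series", "measured", "known", "first", "only" and "open" are said of these compounds alone.

In a functional assay on HT cells (Homo sapiens) for antiproliferative activity, read by fluorescence, with a stated time of 72 h (a higher number here means a weaker inhibitor of growth, a lower number a stronger inhibitor of growth), compound 1 (`CC(C)c1n[nH]c2c(NCc3ccc(-c4ccccn4)cc3)nc(SCCCO)nc12`) gives 109 nM and compound 2 (`CC(C)c1n[nH]c2c(NCc3ccc(-c4ccccn4)cc3)nc(SCCC(N)=O)nc12`) gives 120 nM on the same shared core, a pair separated by a 1.1-fold higher number from compound 1 to compound 2 (0.04 log units; within the scatter) and thus not told apart by this measurement. Compound 3 (`C=CCSc1nc(NCc2ccc(-c3ccccn3)cc2)c2[nH]nc(C(C)C)c2n1`) gives 1010 nM as the highest of the three numbers, which makes it the weakest inhibitor of growth among them. The change to the unmeasured compound 4 (`CCC(CO)Sc1nc(NCc2ccc(-c3ccccn3)cc2)c2[nH]nc(C(C)C)c2n1`) is 1-(hydroxymethyl)propyl in place of allyl on a sulfur and puts 1-(hydroxymethyl)propyl in place of allyl on a sulfur.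

Going by the values given here, no measured compound carries this exact group, but two steps bear on it: a 9.3-fold higher number from compound 1 to compound 3 (0.97 log units; beyond the scatter) and an 8.4-fold higher number from compound 2 to compound 3 (0.93 log units; beyond the scatter) both end at the allyl compound. Compound 4 has a hydroxymethyl end, as compound 1 does, so a modest step towards a lower number is expected, similar to a 9.3-fold higher number from compound 1 to compound 3 (0.97 log units; beyond the scatter) read backwards. The expected move is a 7.2-fold lower number from compound 3 to compound 4 (0.86 log units; beyond the scatter) in this assay for this swap. For compound 4 the estimated value is 140 nM (expected range 45 nM to 450 nM).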

Compound 4, concentration for 50% growth inhibition: 255 nM
Compound 4: the middle estimate sits 1.8-fold (0.26 log units) below what was measured, and the stated range covers the measured number.
By their numbers in this assay, from the lowest: compounds 1 and 2 (each within the scatter of the next); then compound 4; then compound 3.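

In this assay, placing 1-(hydroxymethyl)propyl on the sulfur gives a clearly lower number than allyl (a 4.0-fold lower number from compound 3 to compound 4 (0.60 log units; beyond the scatter)), so the gain is not confined to the two straight chains of compound 1 and compound 2. The gain is only partial, though: compound 4 still ends with a higher number than either 3-hydroxypropyl (a 2.3-fold higher number from compound 1 to compound 4 (0.37 log units; beyond the scatter)) or 2-carbamoylethyl (a 2.1-fold higher number from compound 2 to compound 4 (0.33 log units; beyond the scatter)). A hydroxyl group therefore does not fix the number on its own, since compound 1 and compound 4 both carry one and still differ beyond the scatter.

Nothing shown here explains these differences. From the compounds shown here alone, it also remains open whether an amine or a carboxylic acid at the end of the chain, or a longer chain, would match compound 1.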